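The source may hold more compounds than are shown below. What is called first, only, known or untested is meant among the compounds shown, and "the series" means these compounds.

Compound 1 `Cc1ccc(-c2nnc(COc3cnn(C(C)(C)C)c(=O)c3Cl)o2)cc1` gives 19.9 ug/mL in a functional assay on the whole organism for inhibition, with Mythimna separata as the target, with a stated time of 5 days (a higher number here means that more compound is needed for the effect, a lower number that less compound is needed), the lower of the two numbers recorded. Compound 2 `CC(C)(C)n1ncc(OCc2nnc(-c3c(F)c(F)c(F)c(F)c3F)o2)c(Cl)c1=O` gives 271 ug/mL in this assay, a much larger number that lies well beyond the scatter. Compound 3 `CC(C)(C)n1ncc(OCc2nnc(-c3ccc(Cl)cc3)o2)c(Cl)c1=O` has not yet been measured. It differs from compound 1 by chloro in place of methyl on an aromatic carbon. Among the compounds with values here, no pair of measured compounds shows this exchange on its own, so the expected step is a 1.0-fold higher number from compound 1 to compound 3 (0.00 log units; within the scatter), nothing beyond the usual scatter. Compound 3 is therefore estimated at 20 ug/mL, with a range from 7 ug/mL to 60 ug/mL.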

Compound 3, half-maximal effective concentration: 1.9 ug/mL
Beside the measured number, compound 3's estimate is 11-fold (1.02 log units) above it; the measured number lies below the stated range.
By their numbers in this assay, from the lowest: compound 3; then compound 1; then compound 2.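

Chloro in place of methyl gives a 10-fold lower number from compound 1 to compound 3 (1.02 log units; beyond the scatter) in this assay, so a change of a single heavy atom on the aromatic carbon para to a large group can move this number well beyond the scatter. Compounds 1 and 2 differ in more than one place and could not show this sensitivity to one substituent. Nothing given here explains the size of the step.

The compounds shown leave open how bromo, methoxy or an amine at this place would compare with chloro. They also leave open whether the step would hold with a different group in place of the tert-butyl on the core.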